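Amide-side variation in the series

A few compounds are considered here, and "the series" means these few. Any claim that something is new, unique, unknown or untested is made for them only; others in the source may bear on it.

Measured in an assay on CHO-K1 cells for displacement of a labelled ligand from prostaglandin E2 receptor EP1 subtype (Homo sapiens); a lower number here means a stronger inhibitor, a higher number a weaker inhibitor:
Compound 1 `Cc1cc(C(=O)Nc2ccc(F)cc2)nn1Cc1cc(Cl)ccc1OCc1ccccc1` gives 79.4 nM.
Compound 2 `Cc1cc(C(=O)NCc2ccccc2)nn1Cc1cc(Cl)ccc1OCc1ccccc1` gives 39.8 nM.

Compound 2 has the lower of the two numbers in this assay; its nearest neighbour is compound 1, and a 2.0-fold lower number from compound 1 to compound 2 (0.30 log units; within the scatter), so the two are not separated beyond the scatter. Compound 3 `Cc1cc(C(=O)NCc2ccccn2)nn1Cc1cc(Cl)ccc1OCc1ccccc1` differs from compound 2 by pyridin-2-yl in place of phenyl on a saturated chain carbon bound to an amide-type nitrogen. Among the measured compounds shown here, no measured step exchanges this ring. For the measured compounds named here, the one step known, a 2.0-fold lower number from compound 1 to compound 2 (0.30 log units; within the scatter), bears on it only indirectly: it alters the same group on the amide nitrogen and stays within the scatter. On that basis no step beyond the scatter is expected for compound 3 in this assay, in either direction. The estimate for compound 3 is 50 nM, with a range from 15 nM to 160 nM. The step of a 1.3-fold higher number from compound 2 to compound 3 (0.10 log units; within the scatter) is thus expected to stay within the scatter.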

Compound 3, half-maximal inhibitory concentration: 25.1 nM
Beside the measured number, compound 3's estimate is 2.0-fold (0.30 log units) above it; low and high end bracket the measured number.
By their numbers in this assay, from the lowest: compounds 3, 2 and 1 (each within the scatter of the next, the first and the last beyond it).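

In this assay, pyridin-2-yl is accepted in place of phenyl on the saturated chain carbon bound to an amide-type nitrogen (a 1.6-fold lower number from compound 2 to compound 3 (0.20 log units; within the scatter)), so the added ring nitrogen leaves the two compounds unseparated. Among the compounds shown here, the amide nitrogen substituent now gives a first step beyond the scatter, for (pyridin-2-yl)methyl in place of 4-fluorophenyl (a 3.2-fold lower number from compound 1 to compound 3 (0.50 log units; beyond the scatter)), whereas benzyl in place of 4-fluorophenyl stays within it (a 2.0-fold lower number from compound 1 to compound 2 (0.30 log units; within the scatter)). No supporting evidence bears on either result, so neither step can be given a cause.

The compounds shown leave open how pyridin-3-yl or pyridin-4-yl would read at the same place, and so whether the location of the ring nitrogen matters. Also open, as far as these compounds go, is the effect of a longer chain between the amide nitrogen and the pyridine ring, or of an amine or carboxylic acid on that ring.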